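A methoxymethyl side chain replaces a hydroxymethyl one

The compounds below may be only part of what the source reports. "The series", "measured", "known", "first", "only" and "open" are said of these compounds alone.

In a functional assay on HeLa cells (Homo sapiens) for cytotoxicity, read by WST assay, with a stated time of 48 h (a lower number here means a stronger inhibitor, a higher number a weaker inhibitor), compound 2 `COc1cc(C(c2ccc(O)c(OC)c2)[C@@H](C)[C@@H](C)CO)ccc1O` gives > 100000 nM, which is a limit of the assay and not a number. Compound 1 `COC[C@H](C)[C@H](C)C(c1ccc(O)c(OC)c1)c1ccc(O)c(OC)c1` gives 72000 nM in this assay. The structural change to compound 3 `COC[C@H](C(C)C)C(c1ccc(O)c(OC)c1)c1ccc(O)c(OC)c1` is 1-(methoxymethyl)-2-methylpropyl in place of 2-(hydroxymethyl)-1-methylpropyl on a saturated chain carbon bound to two aromatic carbons. Going by the values given here, only one measured step bears on it: compound 1 and compound 2 differ by a hydrogen in place of methyl on an oxygen on a saturated carbon, which gave an at least 1.3-fold higher number from compound 1 to compound 2 (0.14 log units; that floor lies within the scatter). Among the compounds with values here, compound 3 again carries a methyl on that oxygen, so it may read more like compound 1, though no measured step covers the altered branching of its chain. A small move toward a lower number is therefore expected, an at least 1.4-fold lower number from compound 2 to compound 3 (0.15 log units; that floor lies within the scatter), and it may not exceed the scatter. Compound 3 is estimated at 70000 nM, with an expected range of 30000 nM to 100000 nM.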

Compound 3, half-maximal inhibitory concentration: 76000 nM
Compound 3: the middle estimate sits 1.1-fold (0.04 log units) below what was measured; measured number inside the range.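

In this assay the exchange of 2-(methoxymethyl)-1-methylpropyl for 1-(methoxymethyl)-2-methylpropyl on a saturated chain carbon bound to two aromatic carbons gives a 1.1-fold higher number from compound 1 to compound 3 (0.02 log units; within the scatter) and so, with the methyl on the oxygen kept, this rearranged branching brings no readable shift at this position. The other new step, an at least 1.3-fold lower number from compound 2 to compound 3 (0.11 log units; that floor lies within the scatter) is only a floor, and it lies within the scatter. From the compounds shown here alone, compound 2 stands at a limit of the assay and not at a number, and because of that limit the true size of this step stays unknown: the limit of > 100000 nM in this assay, at which 1 of the 3 values shown sits.

Going by these compounds, whether any chain at this position can move the number beyond the scatter remains open. So does the answer of this position to an amine or a carboxylic acid at the end of the chain, or to a longer chain.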